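Working notes: replacing the aryl group of compound 3

The source may hold more compounds than are shown below. What is called first, only, known or untested is meant among the compounds shown, and "the series" means these compounds.

In an ADME assay on liver (Homo sapiens) for metabolic stability, read by LC-MS, using microsomes and NADPH (a higher number here means that more of the compound is left, a lower number that less of the compound is left), compound 1 (`CCN(Cc1ccc(OCCN2C(=O)CCC2=O)c(C)c1)C(CC(=O)O)c1ccc(Cl)cc1`) gives 100% and compound 2 (`Cc1cc(CN(CC2CCCC2)[C@@H](CC(=O)O)c2ccc(Cl)cc2)ccc1OCCN1C(=O)CCC1=O`) gives 78% in the same test. Compound 3 (`COc1cc(CN(CC(C)C)C(CC(=O)O)c2ccc3c(c2)CCO3)ccc1OCCN1C(=O)CCC1=O`) reads 92% there, within the scatter of compound 1 and beyond the scatter from compound 2, which lies lower. Compound 4 (`COc1cc(CN(CC(C)C)C(CC(=O)O)c2ccc(Cl)c(F)c2)ccc1OCCN1C(=O)CCC1=O`) differs from compound 3 in one place (a group of 8 heavy atoms (6 carbon, 1 fluorine, 1 chlorine; one six-membered aromatic ring of carbon only) in place of a group of 9 heavy atoms (8 carbon, 1 oxygen; one five-membered non-aromatic ring with 1 hetero atom, one six-membered aromatic ring of carbon only), on a saturated chain carbon bound to an amine nitrogen and a saturated chain carbon). Among the measured compounds shown here, no measured pair isolates this change. The expectation therefore rests only on the values of compound 3 (92%) and compound 2 (78%). No step beyond the scatter is expected in this assay, and a slight downward move seems likelier than a rise. The estimated step is small (a number 4 percentage points lower from compound 3 to compound 4 (within the scatter)) and stays within the scatter. For compound 4 the estimated value is 88% with an expected range (72% to 100%).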

Compound 4, percent of the compound remaining in the Homo sapiens assay: 76%
Beside the measured number, compound 4's estimate is 12 percentage points above it, and the stated range covers the measured number.
By their numbers in the Homo sapiens assay, from the lowest: compounds 4 and 2 (each within the scatter of the next); then compounds 3 and 1 (each within the scatter of the next).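

Among the compounds shown here, in the Homo sapiens assay, compound 3 gives 92% and compound 4 gives 76%; this is the first one-place comparison at the saturated chain carbon bound to an amine nitrogen and a saturated chain carbon, and placing 4-chloro-3-fluorophenyl there gives a number 16 percentage points lower from compound 3 to compound 4 (beyond the scatter). The aryl group at this position therefore affects the amount of compound left, which compounds 1, 2 and 3 could not isolate. In a physicochemical assay for solubility, at pH 1.1 (a higher number here means a more soluble compound, a lower number a less soluble compound), compound 3 gives 3000000 nM and compound 4 gives 3000000 nM, and the same change gives no change at the digits printed from compound 3 to compound 4 (within the scatter).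

Going by these compounds, whether a phenyl group carrying a nitrile or a trifluoromethyl group would read closer to compound 3 or compound 4 remains open. The data offer no measured basis for explaining the step.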